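The compounds below may be only part of what the source reports. "The series", "measured", "known", "first", "only" and "open" are said of these compounds alone.

Measured in a functional assay on KYSE-70 cells for antiproliferative activity against KYSE-70 cell line (Homo sapiens), read by MTT assay, with a stated time of 72 h; a higher number here means a weaker inhibitor, a lower number a stronger inhibitor:
- Compound 1 `CC(C)(C)c1ccc(-c2ccc3c(C(=O)Nc4cccc(F)c4)cc(=O)[nH]c3c2)cc1`: > 20000 nM
- Compound 2 `CC(=O)c1ccc(-c2ccc3c(C(=O)Nc4cccc(F)c4)cc(=O)[nH]c3c2)cc1`: > 20000 nM
- Compound 3 `COc1ccc(-c2ccc3c(C(=O)Nc4cccc(F)c4)cc(=O)[nH]c3c2)cc1`: > 20000 nM

Each of these entries is a limit of this assay and not a number. Compound 3 gives > 20000 nM, which is a limit. It has no measured rank within the series, and the evidence is the limit of > 20000 nM in this assay, at which 3 of the 3 values shown sit.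

Compound 4 `O=C(Nc1cccc(F)c1)c1cc(=O)[nH]c2cc(-c3ccsc3)ccc12` differs from compound 3 as follows: thiophen-3-yl in place of 4-methoxyphenyl on an aromatic carbon. In words, thiophen-3-yl stands in place of 4-methoxyphenyl on an aromatic carbon.

The measured steps that bear on this are exchanges of a group on that same aromatic ring: a step that the two limits leave unreadable from compound 1 to compound 2, a step that the two limits leave unreadable from compound 1 to compound 3 and a step that the two limits leave unreadable from compound 2 to compound 3. None of them has a readable size, and none replaces the whole ring. They therefore support no particular size or direction of step in this assay, and the working expectation is that compound 4 stays near the limit.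

The expected step is a number no higher from compound 3 to compound 4 (the limit leaves the size open). Compound 4 is estimated at 20000 nM, within an expected range of 8000 nM to 40000 nM.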

Compound 4, half-maximal inhibitory concentration: 5100 nM
Compound 4: the middle estimate sits 3.9-fold (0.59 log units) above what was measured; measured number outside the range, below it.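

In this assay, the group at this position can move the result: thiophen-3-yl in place of 4-methoxyphenyl gives an at least 3.9-fold lower number from compound 3 to compound 4 (0.59 log units; beyond the scatter). The same exchange gives an at least 3.9-fold lower number from compound 2 to compound 4 (0.59 log units; beyond the scatter) when it replaces 4-acetylphenyl and an at least 3.9-fold lower number from compound 1 to compound 4 (0.59 log units; beyond the scatter) when it replaces 4-(tert-butyl)phenyl, so readable steps now exist at a place where exchanges on the six-membered ring gave none. The steps among compound 1, compound 2 and compound 3 cannot be read, and all three starting values are limits of the assay, not numbers: the limit of > 20000 nM in this assay, at which 3 of the 4 values shown sit.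

The compounds shown do not separate the five-membered ring from its sulfur atom or from the loss of the group on the six-membered ring. Going by these compounds, how unsubstituted phenyl, thiophen-2-yl or a pyridine ring would compare at this place stays open.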